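The compounds below may be only part of what the source reports. "The series", "measured", "known", "first", "only" and "open" are said of these compounds alone.

Measured compounds:
- compound 1, `COc1ccc(NC(=O)CSc2nc3cnccc3[nH]2)cc1OC`: 44.2 nM
- compound 2, `COc1ccc(NC(=O)CSc2nc3cc(Br)cnc3[nH]2)cc1OC`: 192 nM
- compound 3, `COc1ccc(NC(=O)CSc2nc3c(OC(C)C)nc(N)nc3[nH]2)cc1OC`: 11000 nM

In an assay on isolated protein for inhibition of Ectonucleotide pyrophosphatase/phosphodiesterase family member 1 (Homo sapiens), using Lineweaver-Burk analysis (a higher number here means a weaker inhibitor, a lower number a stronger inhibitor), compound 3 gives 11000 nM, the highest of the three numbers, so it is the weakest inhibitor of the set. The nearest to it is compound 2, whose value in this assay is 192 nM, and the furthest is compound 1 with 44.2 nM; both gaps lie well beyond the scatter of repeated measurements.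

Compound 4, `COc1ccc(NC(=O)CSc2nc3c(SC)nc(N)nc3[nH]2)cc1OC`, keeps the core of compound 3 and changes one group: methylsulfanyl in place of isopropoxy on an aromatic carbon. The two groups that are swapped are both small and each carries one hydrogen-bond acceptor. For the measured compounds named here, no measured pair shows what such a swap does at this position, so there is no step to lean on; the change is modest and no movement beyond the scatter is expected.

Compound 4 is therefore expected to give about 9000 nM in this assay, with a range from 3000 nM to 27000 nM. That estimate means a step from compound 3 to compound 4 of a 1.2-fold lower number from compound 3 to compound 4 (0.09 log units; within the scatter), which is expected to stay within the usual scatter.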

Compound 4, inhibition constant: 3650 nM
For compound 4 the middle estimate is 2.5-fold (0.39 log units) above the measured one; measured number inside the range.
By their numbers in this assay, from the lowest: compound 1; then compound 2; then compound 4; then compound 3.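

In this assay, putting methylsulfanyl in place of isopropoxy gives a 3.0-fold lower number from compound 3 to compound 4 (0.48 log units; beyond the scatter) and so shows that the group on this aromatic carbon, next to the ring nitrogen, can change the number. The earlier compounds shown here could not show this, as no two of them differ in only one place. The group that enters has 2 heavy atoms against 4 for the one that leaves, while each carries 1 hydrogen-bond acceptor, but no measurement shown here explains the step.

This single pair cannot tell how a methoxy group or a methylamino group at the same position would compare with either of these two groups. It also leaves open whether the same swap would give a similar step on a core without the amino group.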